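Working notes on cytotoxicity in a sulfonamide series

The source may report more compounds than this note shows. Statements on the series, on what has been measured and on what is new or still open speak of the compounds shown alone.

Compound 1 `O=S(=O)(Nc1ccc2oc(-c3ccccc3)nc2c1)c1ccc(Cl)c(Cl)c1` is the reference point. In an ADME assay on HEK293 cells (Homo sapiens) for cytotoxicity, read by resazurin assay, with a stated time of 48 h (on this read-out lower numbers stand for higher toxicity in this test and higher numbers for lower toxicity in this test), compound 1 gives 71000 nM. Compound 2 `Cc1cccc(S(=O)(=O)Nc2ccc3oc(-c4ccccc4)nc3c2)c1` carries the change (3-methylphenyl in place of 3,4-dichlorophenyl on a sulfonyl sulfur). In this assay compound 2 gives 69000 nM, and the step is a 1.0-fold lower number from compound 1 to compound 2 (0.01 log units; within the scatter), so on this read-out the two aryl groups on the sulfonyl sulfur are not told apart.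

Compound 3 `O=S(=O)(Nc1ccc(-c2nc3ccccc3o2)cc1)c1ccc(Cl)c(Cl)c1` is built from the same atoms as compound 1, joined differently; the difference between the two cores is not broken down here. In this assay compound 3 gives only a limit, > 100000 nM, and no number. This is the limit noted as the limit of > 100000 nM in this assay, at which 1 of the 3 values shown sits.

Compound 4 `Cc1cccc(S(=O)(=O)Nc2ccc(-c3nc4ccccc4o3)cc2)c1` has not been measured. It differs from compound 3 by 3-methylphenyl in place of 3,4-dichlorophenyl on a sulfonyl sulfur, the same change made from compound 1 to compound 2, on a sulfonyl sulfur whose other neighbour is again the sulfonamide nitrogen.

For compound 4 the expected step is a step that the limit leaves unreadable from compound 3 to compound 4, a near-null step that rests on the measured 1.0-fold lower number from compound 1 to compound 2 (0.01 log units; within the scatter) lying within the scatter. Since compound 3 stands at a limit, compound 4 is expected to stand at or past the same limit, and as a number compound 4 is estimated near 120000 nM, most likely between 60000 nM and 250000 nM.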

Compound 4, half-maximal cytotoxic concentration: > 100000 nM
Compound 4: only a limit was reported; the forecaster's own chance of this, stated with the estimate: 65%; the middle value does not contradict the limit.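

Compound 3 and compound 4 are both reported only as limits in this assay, so no step can be read between them: the limit of > 100000 nM in this assay, at which 2 of the 4 values shown sit.

The compounds shown leave open how far compound 3 and compound 4 lie past that limit, and so whether 3-methylphenyl in place of 3,4-dichlorophenyl on a sulfonyl sulfur matters at all on the core of compound 3.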